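The compounds below may be only part of what the source reports. "The series", "measured", "known", "first", "only" and "open" are said of these compounds alone.

Of the compounds shown here, two have been measured in an ADME assay on microsomes from liver (Mus musculus) for metabolic stability, read by LC-MS, with a stated time of 30 min, tested at 1 uM; a higher number here means that more of the compound is left, a lower number that less of the compound is left. Compound 1 (`O=C(NCc1ccc(S(=O)(=O)N2CCCCC2)cc1)c1cnc2nccn2c1`) gives 0.28%, and compound 2 (`O=C(NCc1ccc(S(=O)(=O)c2cc(F)cc(F)c2)cc1)c1cc2cnccc2[nH]1`) gives 63%, the higher of the two numbers and beyond the scatter. Compound 3 (`O=C(NCc1ccc(S(=O)(=O)c2cc(F)cc(F)c2)cc1)c1cnc2nccn2c1`) keeps the rest of compound 2 and changes one place: a group of 9 heavy atoms (6 carbon, 3 nitrogen; one five-membered aromatic ring with 2 hetero atoms, one six-membered aromatic ring with 2 hetero atoms) in place of a group of 9 heavy atoms (7 carbon, 2 nitrogen; one five-membered aromatic ring with 1 hetero atom, one six-membered aromatic ring with 1 hetero atom), on a carbonyl carbon. Going by the values given here, the group that enters on the carbonyl carbon is also the one carried by compound 1, but compound 1 and compound 2 differ elsewhere as well, and no measured step isolates this change. A fall beyond the scatter is nevertheless expected in this assay, resting on compound 1 at 0.28%, though its size is uncertain. The expected change is a number 28 percentage points lower from compound 2 to compound 3 (beyond the scatter). Compound 3 is estimated at 35%, with a range of 8% to 65%.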

Compound 3, percent of the compound remaining: 71%
Estimate against measurement, compound 3: 36 percentage points below; the measured number lies above the stated range.
By their numbers in this assay, from the lowest: compound 1; then compounds 2 and 3 (each within the scatter of the next).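

In this assay the exchange on the carbonyl carbon gives a number 8 percentage points higher from compound 2 to compound 3 (within the scatter) and so stays within the scatter: with 3,5-difluorophenyl on the sulfonyl sulfur, the group that compound 1 also carries on its carbonyl carbon goes with a high number, not a low one. Going by these compounds alone, the exchange of piperidin-1-yl for 3,5-difluorophenyl on the sulfonyl sulfur gives a number 70.7 percentage points higher from compound 1 to compound 3 (beyond the scatter) and is the only single change here that lies beyond the scatter. Nothing at hand gives a reason for either step. The compounds leave open how the number responds to other groups on the sulfonyl sulfur, such as a morpholine or an unsubstituted phenyl. They also leave open whether the exchange on the carbonyl carbon stays within the scatter when piperidin-1-yl sits on the sulfonyl sulfur.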